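This account rests on a few compounds, and the source may have more. Where it says the series, first, only, none or still open, it means among the compounds named here.

Working notes on the series in a functional assay on COLO 205 cells (Homo sapiens) for antiproliferative activity, with a stated time of 72 h; on this read-out lower numbers stand for stronger inhibition and higher numbers for weaker inhibition. Going by the values given here, compound 1 (`C=C1C=CC(=O)[C@@H]2[C@H](Cc3ccc(OCOC)cc3)CC[C@H]12`) gives 219 nM, and compound 2 (`C=C1C=CC(=O)[C@@H]2[C@H](Cc3ccc(OCOC)c(F)c3)CC[C@H]12`) gives 75.7 nM, the lower of the two numbers so far. Compound 3 (`C=C1C=CC(=O)[C@@H]2[C@H](Cc3cc(OC)c(OC)c(OC)c3)CC[C@H]12`) reads > 1000 nM, which is a limit. Next comes compound 4 (`C=C1C=CC(=O)[C@@H]2[C@H](Cc3ccc(F)c(F)c3)CC[C@H]12`), with fluoro in place of methoxymethoxy on an aromatic carbon, ortho to a fluoro group: fluoro in place of methoxymethoxy on an aromatic carbon. Among the compounds with values here, the only measured step, a 2.9-fold lower number from compound 1 to compound 2 (0.46 log units; beyond the scatter), is modest and puts fluoro in place of hydrogen. Within the data shown here, it retains the methoxymethoxy, so no measured pair tests that group's loss, and the guidance is indirect. A modest estimated change toward a higher number is expected in this assay, namely a 2.4-fold higher number from compound 2 to compound 4 (0.38 log units; beyond the scatter). Compound 4 is estimated at 180 nM, with an expected range of 50 nM to 700 nM.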

Compound 4, half-maximal inhibitory concentration: 428 nM
The estimate for compound 4 lay 2.4-fold (0.38 log units) below the measured number, within the range that was stated.
By their numbers in this assay, from the lowest: compound 2; then compounds 1 and 4 (each within the scatter of the next). At a limit, above all of these: compound 3.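

Going by these compounds alone, this is the first direct test of the methoxymethoxy group on this aromatic carbon, para to a large group: with the neighbouring fluoro kept, fluoro in its place gives a 5.7-fold higher number from compound 2 to compound 4 (0.75 log units; beyond the scatter). The fluoro present in compound 2 therefore does not secure that compound's low number without the methoxymethoxy group. The loss still does not take compound 4 to the limit held by compound 3: the limit of > 1000 nM in this assay, at which 1 of the 4 values shown sits.

Open, going by these compounds, is how a hydroxyl, an amine or a longer ether chain would read in this place. Whether the oxygens of methoxymethoxy or its size matter also stays unresolved.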